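Terminal group change on the ethoxy side chain: next step

This account rests on a few compounds, and the source may have more. Where it says the series, first, only, none or still open, it means among the compounds named here.

In a functional assay (Homo sapiens) for antiproliferative activity, read by resazurin assay, with a stated time of 48 h, tested at 20 uM (a higher number here means a stronger effect of the compound at the concentration tested, a lower number a weaker effect), compound 2 `COc1cc(OC)c2c(=O)cc(-c3ccc(OCCN4CCCC4=O)cc3)oc2c1` stands highest of the two numbers, giving 33%. Compound 1 `COc1cc(OC)c2c(=O)cc(-c3ccc(OCCF)cc3)oc2c1` gives 21% in this assay. Within the data shown here, the one measured step at this place, a number 12 percentage points higher from compound 1 to compound 2 (beyond the scatter), is the only guide. Compound 3 `COc1cc(OC)c2c(=O)cc(-c3ccc(OCCN)cc3)oc2c1` differs from compound 2 by amino in place of 2-oxopyrrolidin-1-yl on a saturated chain carbon, two bonds along the chain from an oxygen on an aromatic ring. Among the measured compounds shown here, no measured step brings amino into this place, so only a small shift is expected, and the estimated step is a number 6 percentage points lower from compound 2 to compound 3 (within the scatter). Compound 3 is therefore expected to give about 27%, with a range from 8% to 48%.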

Compound 3, a percentage reported as inhibition, at one concentration (the size of the read-out at that concentration, not a potency): 70%
Compound 3: the middle estimate sits 43 percentage points below what was measured, and the stated range ends below it.
By their numbers in this assay, from the lowest: compound 1; then compound 2; then compound 3.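

In this assay the change to amino gives a number 37 percentage points higher from compound 2 to compound 3 (beyond the scatter) and gives a number 49 percentage points higher from compound 1 to compound 3 (beyond the scatter) at this place on the chain. The terminal group therefore matters far more than the first pair showed, and the group with a single heavy atom and one hydrogen-bond donor stands above both larger or donor-free alternatives shown. No data here account for this gain.

Still open, going by these compounds, is whether a dimethylamino group, with no hydrogen-bond donor, would hold this level. On these data alone, a longer chain ending in amino is equally open.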